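Hydroxy for Isopropylsulfonyl on a Shared Core

A few compounds are considered here, and "the series" means these few. Any claim that something is new, unique, unknown or untested is made for them only; others in the source may bear on it.

Of the compounds shown here, two of a common core have been measured so far. Compound 1 `N#CCCCn1c(Cn2c(=O)n(Cc3ccc(C#N)cc3)c3ccncc32)nc2ccccc21` gives 36800 nM in an ADME assay on HEp-2 cells (Homo sapiens) for cytotoxicity; on this read-out higher numbers stand for lower toxicity in this test and lower numbers for higher toxicity in this test. Compound 2 `CC(C)S(=O)(=O)CCCn1c(Cn2c(=O)n(C3CC3)c3ccncc32)nc2ccccc21` gives 49200 nM in this assay, the higher of the two numbers, though its gap to compound 1 lies within the scatter of the measurement, so the two cannot be told apart on these figures.

Compound 3 `O=c1n(Cc2nc3ccccc3n2CCCO)c2cnccc2n1C1CC1` has not yet been measured. It differs from compound 2 in one place: hydroxy in place of isopropylsulfonyl on a saturated chain carbon, three bonds along the chain from an aromatic nitrogen. Going by the values given here, no step between measured compounds of this kind is at hand, so nothing in the data points to a change in this assay beyond the scatter, in either direction.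

On that basis compound 3 is expected to give about 55000 nM in this assay, with a likely range from 25000 nM to 120000 nM. The step that this estimate implies, a 1.1-fold higher number from compound 2 to compound 3 (0.05 log units; within the scatter), is expected to stay within the scatter.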

Compound 3, half-maximal cytotoxic concentration: 245000 nM
The estimate for compound 3 lay 4.5-fold (0.65 log units) below the measured number; measured number outside the range, above it.
By their numbers in this assay, from the lowest: compounds 1 and 2 (each within the scatter of the next); then compound 3.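

Going by these compounds alone, the exchange of isopropylsulfonyl for hydroxy on a saturated chain carbon, three bonds along the chain from an aromatic nitrogen, gives the first step that can be read at this position in this assay, namely a 5.0-fold higher number from compound 2 to compound 3 (0.70 log units; beyond the scatter), and this step lies beyond the scatter. It shows that what sits at the end of this chain can move the read-out, with the 3-hydroxypropyl compound on the side of lower toxicity in this test compared with the 3-(isopropylsulfonyl)propyl compound, though this rests on a single pair of compounds. No supporting data bear on what lies behind this step.

The compounds shown leave open whether the higher number goes with the hydroxy itself or simply with the loss of isopropylsulfonyl, a question that an amine or a carboxylic acid in place of the hydroxy, or a longer chain carrying it, would bear on. They also leave open whether the same exchange would give a step of similar size with a group other than the cyclopropyl that compound 2 and compound 3 share on the core.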